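Compound 3 to compound 4: a flat series

A few compounds are considered here, and "the series" means these few. Any claim that something is new, unique, unknown or untested is made for them only; others in the source may bear on it.

compound 1 `O=C(/C=C/c1ccccc1Br)NNC(=O)c1ccc2c(c1)OCCO2`: 315000 nM
compound 2 `O=C(/C=C/c1ccccc1)NNC(=O)c1ccc2c(c1)OCCO2`: 312000 nM
compound 3 `Cc1ccccc1/C=C/C(=O)NNC(=O)c1ccc2c(c1)OCCO2`: 268000 nM

In an ADME assay on cells (Macrophage) for cytotoxicity, read by MTT assay, with a stated time of 24 h (a lower number here means that less compound is tolerated, a higher number that more compound is tolerated), compound 3 gives 268000 nM, within the scatter of both compound 1 and compound 2. The next compound is compound 4 `COc1cccc(/C=C/C(=O)NNC(=O)c2ccc3c(c2)OCCO3)c1`. The change is 3-methoxyphenyl in place of 2-methylphenyl on a double-bonded chain carbon bound to a double-bonded chain carbon. For the measured compounds named here, three measured steps bear on it only indirectly: a 1.0-fold lower number from compound 1 to compound 2 (0.00 log units; within the scatter), a 1.2-fold lower number from compound 1 to compound 3 (0.07 log units; within the scatter) and a 1.2-fold lower number from compound 2 to compound 3 (0.07 log units; within the scatter). Going by the values given here, all stay within the scatter, and no measured compound carries a 3-methoxyphenyl group. The expected change is therefore none beyond the scatter, with an estimated 1.1-fold higher number from compound 3 to compound 4 (0.03 log units; within the scatter). Compound 4 is expected at 290000 nM, with an estimated range of 170000 nM to 480000 nM.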

Compound 4, half-maximal cytotoxic concentration: 398000 nM
For compound 4 the middle estimate is 1.4-fold (0.14 log units) below the measured one, within the range that was stated.
By their numbers in this assay, from the lowest: compounds 3, 2, 1 and 4 (each within the scatter of the next).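

In this assay, the change to 3-methoxyphenyl on a double-bonded chain carbon bound to a double-bonded chain carbon gives a 1.5-fold higher number from compound 3 to compound 4 (0.17 log units; within the scatter) and the comparison with the unsubstituted phenyl compound gives a 1.3-fold higher number from compound 2 to compound 4 (0.11 log units; within the scatter) while the comparison with the 2-bromophenyl compound gives a 1.3-fold higher number from compound 1 to compound 4 (0.10 log units; within the scatter). An aryl group carrying an oxygen and a hydrogen-bond acceptor therefore leaves the series as flat as bromo and methyl did. Nothing available explains this flatness. On these data alone, whether an amine or a carboxylic acid on this aromatic ring would stay within the scatter remains open. So does the effect of a longer chain in place of the double-bonded chain.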